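Cyclopropyl for vinyl on a thiophene-bearing amine series

The compounds below may be only part of what the source reports. "The series", "measured", "known", "first", "only" and "open" are said of these compounds alone.

Measured compounds:
- Compound 1, `CCCc1csc(CN[C@@H]2C[C@H]3C[C@@H]([C@H]2C)C3(C)C)c1`: 12500 nM
- Compound 2, `C=Cc1ccsc1CN[C@@H]1C[C@H]2C[C@@H]([C@H]1C)C2(C)C`: 50000 nM
- Compound 3, `C[C@H]1[C@H](NCc2ccc(C(C)(C)C)s2)C[C@H]2C[C@@H]1C2(C)C`: 780 nM

Three compounds sharing the same bicyclic amine core were examined in an ADME assay on MDCK cells (Canis lupus familiaris) for cytotoxicity, read by microscopy, with a stated time of 48 h; on this read-out lower numbers stand for higher toxicity in this test and higher numbers for lower toxicity in this test. Compound 1 gives 12500 nM in this assay, compound 2 gives 50000 nM, and compound 3 gives 780 nM. Compound 2 stands at the highest number of the three, that is, the least toxic in this test; its nearest neighbour is compound 1 and its furthest is compound 3, both steps lying beyond the usual scatter.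

The unmeasured compound 4, `C[C@H]1[C@H](NCc2sccc2C2CC2)C[C@H]2C[C@@H]1C2(C)C`, differs from compound 2 in one place: cyclopropyl in place of vinyl on an aromatic carbon. The cyclopropyl group is larger than the vinyl group it replaces, and within the measured set the larger substituents on the five-membered ring go with lower numbers, as compound 3 shows against compound 2. Compound 4 is therefore expected to show a moderate step downward, a 2.0-fold lower number from compound 2 to compound 4 (0.30 log units; within the scatter), though one that may still fall within the scatter. The estimate for compound 4 is 25000 nM, with a range from 8000 nM to 80000 nM.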

Compound 4, minimum cytotoxic concentration: 25000 nM
For compound 4 middle estimate and measured number coincide at the digits printed, and the stated range covers the measured number.
By their numbers in this assay, from the lowest: compound 3; then compounds 1, 4 and 2 (each within the scatter of the next, the first and the last beyond it).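

In this assay, among these compounds, the exchange of vinyl for cyclopropyl gives a 2.0-fold lower number from compound 2 to compound 4 (0.30 log units; within the scatter) and is the first step in this set that isolates one place. On this aromatic carbon, next to the ring atom that bears a large group, the double bond outside aromatic rings can give way to a three-membered ring of carbon without the two values leaving each other's scatter, so the two groups cannot be told apart in this test. No measurement shown explains this result.

On these data alone, what an amine, a carboxylic acid or a longer chain on this aromatic carbon would give remains open. So does whether cyclopropyl and vinyl would again fall within the scatter of each other on another carbon of the five-membered ring.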